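A few compounds are considered here, and "the series" means these few. Any claim that something is new, unique, unknown or untested is made for them only; others in the source may bear on it.

Compound 3 `COc1ccc(-c2c(CNC(C)(C)C)c(C(=O)O)nn2-c2ccccc2)cc1` gives no number in a functional assay on K562 cells (Homo sapiens) for inhibition, read by sulforhodamine B assay, with a stated time of 48 h; on this read-out higher numbers stand for weaker inhibition of growth and lower numbers for stronger inhibition of growth. Its result is a limit, > 659000 nM. Compound 2 `CC(C)(C)NCc1c(C(=O)O)nn(-c2ccccc2)c1-c1ccc(Br)cc1` also yields only a limit, > 585000 nM. Between these two lies a step that the two limits leave unreadable from compound 2 to compound 3, with methoxy in place of bromo on an aromatic carbon, so that change shows no size at all. Among the compounds with values here, compound 1 `CCOC(=O)c1nn(-c2ccccc2)c(-c2ccc(OC)cc2)c1CNC(C)(C)C` is the only one with true readings in this assay, at 66600 nM; 29800 nM (2 entries). Both readings sit lower than the limits of compound 2 and compound 3.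

Compound 4 `COc1ccc(-c2c(CNC(C)(C)C)c(C(=O)O)nn2-c2ccc(Cl)cc2)cc1` differs from compound 3 at one place: chloro in place of hydrogen on an aromatic carbon. This is chloro in place of hydrogen on an aromatic carbon, turning phenyl into 4-chlorophenyl. Within the data shown here, no measured step covers this change, and the one nearby step cannot be sized, so the closest guide is compound 3 itself, with its limit of > 659000 nM. With so little evidence, no step beyond the usual scatter is expected, although any real number that did appear could only lie on the stronger side. The expected step is an at least 1.0-fold lower number from compound 3 to compound 4 (0.04 log units; that floor lies within the scatter). For compound 4 the estimated value is 600000 nM, with an expected range from 250000 nM to 700000 nM.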

Compound 4, concentration for 50% growth inhibition: > 605000 nM
Compound 4: only a limit was reported; the forecaster's own chance of this, stated with the estimate: 85%; middle value at least 1.0-fold (0.00 log units) from the limit.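

Compound 3 and compound 4 each give only a limit, so no size can be read for the change from phenyl to 4-chlorophenyl. The compounds shown leave open how strongly compound 2, compound 3 and compound 4 inhibit growth in this assay, and whether chloro in place of hydrogen changes that inhibition at all.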